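A few compounds are considered here, and "the series" means these few. Any claim that something is new, unique, unknown or untested is made for them only; others in the source may bear on it.

Working notes on the series.

Among the measured compounds shown here, in a functional assay on MCF7 cells (Homo sapiens) for inhibition, with a stated time of 48 h (on this read-out higher numbers stand for weaker inhibition and lower numbers for stronger inhibition), the numbers so far span a wide range. Compound 1 `COc1cc(Sc2c(C)[nH]c3ccccc23)cc(OC)c1OC` gives 46 nM. Compound 2 `Cc1cc(C)cc(Sc2c[nH]c3ccc(Cl)cc23)c1` gives 1200 nM. Compound 3 `COc1cc(Sc2c[nH]c3ccc(Br)cc23)cc(OC)c1OC` gives 43 nM, the lowest number of the three; its nearest neighbour is compound 1, whose number lies within the scatter of that of compound 3, so no order between these two can be read, while compound 2 stands far beyond the scatter from both.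

The next compound in line is compound 4 `COc1cc(Sc2c[nH]c3ccc(O)cc23)cc(OC)c1OC`, which differs from compound 3 in one place: hydroxy in place of bromo on an aromatic carbon. For the measured compounds named here, no measured pair in this assay isolates this particular change, so its size is not known. What the numbers do show is that compound 1 and compound 3, which carry different groups on the fused ring system while sharing the rest of the structure, give values within the scatter of each other; the trimethoxy-bearing compounds are the two strong ones, and compound 2 lacks that part.

On that basis the step from compound 3 to compound 4 is expected to be small, a 1.2-fold higher number from compound 3 to compound 4 (0.07 log units; within the scatter), in no firm direction, and most likely within the scatter. Compound 4 is accordingly estimated at 50 nM in this assay, with a range from 12 nM to 200 nM.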

Compound 4, half-maximal inhibitory concentration: 190 nM
Compound 4: middle estimate off by 3.8-fold (0.58 log units), on the low side; measured number inside the range.
By their numbers in this assay, from the lowest: compounds 3 and 1 (each within the scatter of the next); then compound 4; then compound 2.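

In this assay, the aromatic carbon that is meta to a fused ring and para to a fused ring proves sensitive to what it carries: hydroxy in place of bromo gives a 4.4-fold higher number from compound 3 to compound 4 (0.65 log units; beyond the scatter). Among the compounds shown here, this is the first step that isolates a single change, and it lies beyond the scatter, so the group at this position matters even when the rest of the structure is kept. The exchange replaces one heavy atom with one heavy atom and adds a hydrogen-bond donor and a hydrogen-bond acceptor, but these counts describe the change without accounting for the step, and no measurement at hand bears on its cause.

For the compounds shown here, the single pair does not separate a loss tied to bromo from a loss tied to hydroxy, and it remains open how a methoxy group, an amine or a plain hydrogen at the same aromatic carbon would read out. Also open, on these data alone, is whether the same exchange gives a step of similar size on a core carrying other substituents, as this pair is the only one that isolates it.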